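Replacing the aryl group on the amine nitrogen

The source may report more compounds than this note shows. Statements on the series, on what has been measured and on what is new or still open speak of the compounds shown alone.

Compound 1 `Cc1ccc(S(=O)(=O)/N=C(/CCNC2=CC(=O)c3ccccc3C2=O)Nc2ccccc2I)cc1`: 11700 nM
Compound 2 `Cc1ccc(S(=O)(=O)/N=C(/CCNC2=CC(=O)c3ccccc3C2=O)Nc2cccc(C)c2)cc1`: 10200 nM

In a functional assay on DU-145 cells (Homo sapiens) for cytotoxicity, read by MTT assay, with a stated time of 48 h (on this read-out higher numbers stand for weaker inhibition and lower numbers for stronger inhibition), compound 1 gives 11700 nM, the highest of the two numbers, while compound 2 gives 10200 nM, so that a 1.1-fold lower number from compound 1 to compound 2 (0.06 log units; within the scatter). Compound 3 `COc1ccc(N/C(CCNC2=CC(=O)c3ccccc3C2=O)=N\S(=O)(=O)c2ccc(C)cc2)c(OC)c1` differs from compound 1 by 2,4-dimethoxyphenyl in place of 2-iodophenyl on an amine nitrogen. Among the compounds with values here, only one measured step bears on this, an aryl swap at the same amine nitrogen, and it was small: a 1.1-fold lower number from compound 1 to compound 2 (0.06 log units; within the scatter). No change beyond the scatter is therefore expected. Compound 3 is estimated at 11000 nM (5000 nM to 25000 nM), which means a step of a 1.1-fold lower number from compound 1 to compound 3 (0.03 log units; within the scatter).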

Compound 3, half-maximal inhibitory concentration: 67300 nM
The estimate for compound 3 lay 6.1-fold (0.79 log units) below the measured number; the whole stated range lies below it.
By their numbers in this assay, from the lowest: compounds 2 and 1 (each within the scatter of the next); then compound 3.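

Swapping the aryl group on this amine nitrogen can change the number after all. In this assay, 2,4-dimethoxyphenyl gives weaker inhibition than 2-iodophenyl (a 5.8-fold higher number from compound 1 to compound 3 (0.76 log units; beyond the scatter)) and than 3-methylphenyl (a 6.6-fold higher number from compound 2 to compound 3 (0.82 log units; beyond the scatter)), while those two groups stay within the scatter of each other. Nothing measured here explains this loss.

A 2-methoxyphenyl or 4-methoxyphenyl group on the same nitrogen would show whether a single methoxy group is enough for the change or both are needed. A plain phenyl group would give all three compounds a common reference.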